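Working notes: swapping the amino substituent in a weak series

A few compounds are considered here, and "the series" means these few. Any claim that something is new, unique, unknown or untested is made for them only; others in the source may bear on it.

Compound 1, `CCOC(=O)CN(Cc1ccccc1)c1nc(Nc2ccccc2)ncc1[N+](=O)[O-]`: in a functional assay on MDA-MB-231 cells (Homo sapiens) for antiproliferative activity, read by MTT assay, with a stated time of 48 h (a higher number here means a weaker inhibitor, a lower number a stronger inhibitor), compound 1 gives only a limit, > 100000 nM.
Compound 2, `CCOC(=O)CNc1ncc([N+](=O)[O-])c(N(CC(=O)OCC)Cc2ccccc2)n1`: in this assay compound 2 gives 92500 nM.

Within the data shown here, compound 2 holds the only numerical value in this assay; the other entry is a limit, (the limit of > 100000 nM in this assay, at which 1 of the 2 values shown sits). Among the measured compounds shown here, the single measured step, an at least 1.0-fold lower number from compound 1 to compound 2 (0.03 log units; that floor lies within the scatter), is a floor that lies within the scatter, so phenyl against (ethoxycarbonyl)methyl on that nitrogen made no resolvable difference.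

Compound 3, `CCOC(=O)CN(Cc1ccccc1)c1nc(Nc2ccc(Cl)cc2)ncc1[N+](=O)[O-]`, differs from compound 2 by 4-chlorophenyl in place of (ethoxycarbonyl)methyl on a nitrogen on an aromatic ring. For the measured compounds named here, this largely reverses the one measured change and adds a chlorine to the ring. Since the step from compound 1 to compound 2 showed nothing beyond the scatter, the expected step of a 1.1-fold higher number from compound 2 to compound 3 (0.03 log units; within the scatter) is likewise none beyond the scatter, with a real chance that only a limit is returned. Compound 3 is therefore estimated at 100000 nM, within 40000 nM to 300000 nM.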

Compound 3, half-maximal inhibitory concentration: 34400 nM
Estimate against measurement, compound 3: 2.9-fold (0.46 log units) above, outside the stated range (below it).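

Among these compounds, the step at the nitrogen on an aromatic ring is the first to clear the scatter: a 2.7-fold lower number from compound 2 to compound 3 (0.43 log units; beyond the scatter), with 4-chlorophenyl in place of (ethoxycarbonyl)methyl. Chloro in place of hydrogen on an aromatic carbon also gives a readable difference, an at least 2.9-fold lower number from compound 1 to compound 3 (0.46 log units; beyond the scatter), so this single change separates compound 3 from compound 1 where the earlier step resolved nothing. That second step is only a floor, as compound 1 is recorded solely as a limit: the limit of > 100000 nM in this assay, at which 1 of the 3 values shown sits.

Going by these compounds, whether bromo, methoxy or trifluoromethyl in place of that chloro would keep or extend the step remains open. Also open, on these data alone, is how this assay would respond to a carboxylic acid in place of the ethyl ester on the shared core.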